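This account rests on a few compounds, and the source may have more. Where it says the series, first, only, none or still open, it means among the compounds named here.

Of the compounds shown here, three have so far been measured in a functional assay on HeLa cells (Homo sapiens) for inhibition; a lower number here means a stronger inhibitor, a higher number a weaker inhibitor. Compound 1 `Nc1ncnc2c1ncn2/C=C/C=O` gives 30000 nM, and compound 2 `O=C/C=C/n1ccc(=O)[nH]c1=O` gives 30000 nM. Compound 3 `Cc1cn([C@H]2C[C@H](O)[C@@H](CO)O2)c(=O)n(/C=C/C=O)c1=O` gives 500 nM in this assay, the lowest of the three numbers; both compound 1 and compound 2 stand at a higher number than compound 3, and each of those gaps lies beyond the scatter.

Compound 4 `Cc1cn([C@@H]2O[C@H](CO)[C@@H](O)[C@H]2O)c(=O)n(/C=C/C=O)c1=O` has not yet been measured in this assay. It differs from compound 3 in one place: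

hydroxy in place of hydrogen on a saturated ring carbon

Among the measured compounds shown here, no pair of measured compounds differs in just this way, so nothing measured here shows directly what the change does, and compound 1 and compound 2 are too far from compound 3 in structure to speak to it. The rest of the structure of compound 3 is kept. The expectation is that the number for compound 4 moves only a little, toward a somewhat weaker inhibitor, as the step of a 2.0-fold higher number from compound 3 to compound 4 (0.30 log units; within the scatter) expresses, and that this step may well fall within the scatter. Compound 4 is estimated to give 1000 nM in this assay, with a range from 300 nM to 4000 nM.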

Compound 4, half-maximal inhibitory concentration: > 100000 nM
Compound 4 ended at the assay's limit; the forecaster's own chance of this, stated with the estimate: 10%; middle value at least 100-fold (2.00 log units) from the limit.
By their numbers in this assay, from the lowest: compound 3; then compounds 1 and 2 (each within the scatter of the next). At a limit, above all of these: compound 4.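

In this assay, hydroxy in place of hydrogen on a saturated ring carbon gives an at least 200-fold higher number from compound 3 to compound 4 (2.30 log units; beyond the scatter), the first single-place change that can be read among these compounds, and it shows that this ring carbon is far from indifferent to what it carries. Compound 4 stands at a limit of the assay, > 100000 nM, so the step gives only a lower bound on the size of the change. Among the compounds shown, this limit is reached only once: the limit of > 100000 nM in this assay, at which 1 of the 4 values shown sits.

The compounds shown carry only hydrogen or hydroxy at this carbon, so it remains open whether the sharp change belongs to hydroxy alone or would follow any group placed there. A methoxy group, a fluorine atom or an amine at the same ring carbon would address this, as would hydroxy in the opposite orientation.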